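A few compounds are considered here, and "the series" means these few. Any claim that something is new, unique, unknown or untested is made for them only; others in the source may bear on it.

Of the compounds shown here, three built on one shared core have been tested in a functional assay on MCF7 cells (Homo sapiens), tested at 5 uM; a higher number here means a weaker effect of the compound at the concentration tested, a lower number a stronger effect. Compound 1 `CC(C)=CCOc1c(C)c(C)c2c(c1C)CCC(C)(COc1ccc(/C=C3\SC(=O)NC3=O)cc1C)O2` gives 56% in this assay. Compound 2 `C=CCOc1c(C)c(C)c2c(c1C)CCC(C)(COc1ccc(/C=C3\SC(=O)NC3=O)cc1C)O2` gives 24%. Compound 3 `C=CCOc1c(C)c(C)c2c(c1C)CCC(C)(COc1ccc(/C=C3\SC(=O)NC3=O)cc1OCC)O2` gives 87%, the highest of the three numbers, with every step to the others beyond the scatter.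

Compound 2 and compound 1 differ by 2-methylprop-1-en-1-yl in place of vinyl on a saturated chain carbon bound to an oxygen on an aromatic ring, and the step of a number 32 percentage points higher from compound 2 to compound 1 (beyond the scatter) is large. Compound 2 and compound 3 differ in their cores by ethoxy in place of methyl on an aromatic carbon, and the step of a number 63 percentage points higher from compound 2 to compound 3 (beyond the scatter) is larger still.

Compound 4 `CCOc1cc(/C=C2\SC(=O)NC2=O)ccc1OCC1(C)CCc2c(C)c(OCC=C(C)C)c(C)c(C)c2O1` has not yet been measured. It differs from compound 3 by 2-methylprop-1-en-1-yl in place of vinyl on a saturated chain carbon bound to an oxygen on an aromatic ring. This is the same change that turns compound 2 into compound 1, now made on the core of compound 3; the place of the change is described in the same words for both pairs, so it is the same change, not merely the same kind. The same change on the core of compound 2 gave the step of a number 32 percentage points higher from compound 2 to compound 1 (beyond the scatter), and a rise is expected for compound 4 as well. The number of compound 3, at 87%, is already high, so the rise expected on top of it is a smaller one. For compound 4 the expected step is a number 8 percentage points higher from compound 3 to compound 4 (within the scatter), smaller than the earlier one. The estimate for compound 4 is 95%, with a range from 80% to 102%.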

Compound 4, a percentage reported as activity, at one concentration (the size of the read-out at that concentration, not a potency): 84%
For compound 4 the middle estimate is 11 percentage points above the measured one; the range from low to high includes it.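

Carried onto the core bearing ethoxy, the change from allyl to 3-methylbut-2-en-1-yl gives a number 3 percentage points lower from compound 3 to compound 4 (within the scatter), so the rise seen on the core bearing methyl does not repeat in this assay: the same change on two cores in this assay, a number 32 percentage points higher (beyond the scatter) from compound 2 to compound 1 and a number 3 percentage points lower (within the scatter) from compound 3 to compound 4, 35 percentage points apart, beyond the scatter of two such steps

The change from methyl to ethoxy keeps its direction but not its size, giving a number 28 percentage points higher from compound 1 to compound 4 (beyond the scatter) when the 3-methylbut-2-en-1-yl group is present: the same change on two cores in this assay, a number 63 percentage points higher (beyond the scatter) from compound 2 to compound 3 and a number 28 percentage points higher (beyond the scatter) from compound 1 to compound 4, 35 percentage points apart, beyond the scatter of two such steps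

Within these four compounds, then, the effect of each change depends on the group present at the other place, so a step measured on one core cannot simply be transferred to another, but the data do not show why the steps differ, and they give no rule for any core beyond these.

The compounds shown leave open how a saturated butyl chain would behave in place of the allyl or 3-methylbut-2-en-1-yl group, and how a methoxy group or a chlorine would behave on the aromatic carbon that carries methyl or ethoxy. They also leave open whether the same dependence between the two places would appear with such groups.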